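The source may report more compounds than this note shows. Statements on the series, on what has been measured and on what is new or still open speak of the compounds shown alone.

Measured so far in a physicochemical assay for acid dissociation:

- compound 1 `c1ccc(CCc2ccc3c(NCCCNCc4ccco4)ccnc3c2)cc1`: 9.47
- compound 2 `COc1ccccc1Oc1ccc2c(NCCCNCc3ccco3)ccnc2c1`: 9.28

Among the measured compounds shown here, with only one other measured compound to compare against, compound 2 at 9.28 cannot be told apart from compound 1, so it marks no end of a range.

The next compound, compound 3 `c1coc(CNCCCNc2ccnc3cc(CC4CCCCC4)ccc23)c1`, keeps the shared core and the side chain and changes one group: cyclohexylmethyl in place of 2-methoxyphenoxy on an aromatic carbon. In words, this is cyclohexylmethyl in place of 2-methoxyphenoxy on an aromatic carbon.

For the measured compounds named here, one measured step bears on this change. Putting 2-methoxyphenoxy in place of phenethyl on an aromatic carbon gave a number 0.19 log units lower from compound 1 to compound 2 (within the scatter). Compound 3 now removes that same 2-methoxyphenoxy group and brings in a different one. Going by the values given here, this single step is thin evidence, and no measured compound yet carries cyclohexylmethyl. Even so, the only exchange seen so far stayed within the scatter, so no shift beyond the scatter is expected in this assay.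

The estimated step is a number 0.14 log units higher from compound 2 to compound 3 (within the scatter). Compound 3 is expected at 9.42, with an estimated range of 9.1 to 9.72.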

Compound 3, acid dissociation constant: 9.47
For compound 3 the middle estimate is 0.05 log units below the measured one, and the stated range covers the measured number.
By their numbers in this assay, from the lowest: compounds 2, 1 and 3 (each within the scatter of the next).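

In this assay, exchanging 2-methoxyphenoxy for cyclohexylmethyl gave a number 0.19 log units higher from compound 2 to compound 3 (within the scatter) and thereby added a second exchange at this aromatic carbon that stays inside the scatter. This exchange differs in kind from the earlier one: the group that enters has a six-membered non-aromatic ring of carbon only and no hydrogen-bond acceptors, whereas the group that leaves has a six-membered aromatic ring and two hydrogen-bond acceptors, yet the reading does not separate from that of compound 2. The comparison with the phenethyl compound adds a direct test of ring type, since cyclohexyl in place of benzyl on the saturated chain carbon bound to the aromatic carbon gave no change at the digits printed from compound 1 to compound 3 (within the scatter) and so, across compounds 1, 2 and 3, none of these three groups stands apart from the others in this measurement.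

Whether this holds for a group of another kind on the same carbon, such as an amine or a carboxylic acid, remains open, as all three groups shown are large and uncharged. Nothing given here accounts for why the three readings stay together.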